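This account rests on a few compounds, and the source may have more. Where it says the series, first, only, none or still open, it means among the compounds named here.

Measured so far in a functional assay on HEK293 cells for agonist activity at Neuronal acetylcholine receptor; alpha3/beta4 (Homo sapiens), read by FLIPR; a lower number here means that less compound is needed, a higher number that more compound is needed for the effect:
compound 1 `Cc1cc(N2CC[C@@H]3CN[C@@H]3C2)cnc1Cl` gives 71 nM
compound 2 `N#Cc1cncc(N2CC[C@@H]3CN[C@@H]3C2)c1` gives 490 nM
compound 3 `COc1cncc(N2CC[C@@H]3CN[C@@H]3C2)c1` gives 4500 nM

Compound 3 stands highest of the three numbers in this assay; its nearest neighbour is compound 2, and compound 1 lies furthest below it. The next compound, compound 4 `Cc1cncc(N2CC[C@@H]3CN[C@@H]3C2)c1`, differs from compound 3 by methyl in place of methoxy on an aromatic carbon. Within the data shown here, the one measured step at this position is a 9.2-fold higher number from compound 2 to compound 3 (0.96 log units; beyond the scatter), so swapping the group here has moved the number by a modest amount. Compound 1 also carries a methyl, but with a second substituent and a different arrangement, so it gives no single-site comparison. The step from compound 3 to compound 4 is therefore expected to be a modest decrease, a 3.8-fold lower number from compound 3 to compound 4 (0.57 log units; beyond the scatter). Compound 4 is estimated at 1200 nM, within a range of 300 nM to 4500 nM.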

Compound 4, half-maximal effective concentration: 1400 nM
Compound 4: middle estimate off by 1.2-fold (0.07 log units), on the low side, within the range that was stated.
By their numbers in this assay, from the lowest: compound 1; then compound 2; then compound 4; then compound 3.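

In this assay, methyl at this aromatic carbon gives (a 3.2-fold lower number from compound 3 to compound 4 (0.51 log units; beyond the scatter)) and (a 2.9-fold higher number from compound 2 to compound 4 (0.46 log units; beyond the scatter)), so the three groups rank cyano, methyl, methoxy from the lowest number up. The chloro of compound 1 counts for more than any swap seen at this carbon so far (a 20-fold higher number from compound 1 to compound 4 (1.29 log units; beyond the scatter)). No evidence at hand accounts for this ranking.

Open, as far as these compounds go, is whether chloro brings a similar step when cyano replaces methyl. Also open, from the compounds shown here alone, is where an amine or an ethyl group would rank at this carbon.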